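Removing the chlorobenzyl thioether from a triazolopyrimidine chalcone

The compounds below may be only part of what the source reports. "The series", "measured", "known", "first", "only" and "open" are said of these compounds alone.

Compound 1 `Cc1cc(Nc2ccc(C(=O)/C=C/c3cccc(Br)n3)cc2)n2nc(SCc3ccc(Cl)cc3)nc2n1` was tested in a functional assay on MGC-803 cells (Homo sapiens) for inhibition, read by sulforhodamine B assay, with a stated time of 72 h, tested at 10 uM (a higher number here means more inhibition at the concentration tested (going by the name of the read-out), a lower number less inhibition), and gave 90.2%. Among the three compounds measured, compound 1 stands highest. Going by the values given here, compound 2 `Cc1nc2nc(SCc3ccc(Cl)cc3)nn2c(Nc2ccc(C(=O)/C=C/c3cccc(Br)n3)cc2)c1C` gave 72.5%, and the only single-point step in the set, a number 17.7 percentage points lower from compound 1 to compound 2 (beyond the scatter), is a methyl in place of hydrogen on an aromatic carbon. Compound 3 `Cc1cc(Nc2ccccc2)n2nc(SCc3nc4ccccc4[nH]3)nc2n1` gave 22.4%; it differs from compound 1 in more than one place, so only its value can be compared.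

The compound now in question, compound 4 `Cc1cc(Nc2ccc(C(=O)/C=C/c3cccc(Br)n3)cc2)n2ncnc2n1`, differs from compound 1 by hydrogen in place of (4-chlorobenzyl)sulfanyl on an aromatic carbon. Among the compounds with values here, no measured step matches this change: the step from compound 1 to compound 2 concerns a methyl elsewhere, and compound 3 carries a different sulfur-linked group together with other changes. The low value of compound 3 shows that a compound lacking the bromopyridyl enone part gives a much lower number in this assay, while compound 4 keeps that part. Compound 4 is therefore expected to give a number that is lower than that of compound 1 but well above that of compound 3, estimated at 60% with a range from 30% to 85%, so the expected step is a number 30.2 percentage points lower from compound 1 to compound 4 (beyond the scatter).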

Compound 4, a percentage reported as inhibition, at one concentration (the size of the read-out at that concentration, not a potency): 58.4%
For compound 4 the middle estimate is 1.6 percentage points above the measured one, and the stated range covers the measured number.
By their numbers in this assay, from the lowest: compound 3; then compound 4; then compound 2; then compound 1.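

Replacing the (4-chlorobenzyl)sulfanyl group on this aromatic carbon with hydrogen gives, in this assay, a number 31.8 percentage points lower from compound 1 to compound 4 (beyond the scatter), so this substituent clearly contributes to the number measured for compound 1. The group is not needed for all of the inhibition, however, since compound 4, with only hydrogen at this position, still gives 58.4%. Nothing measured here explains the drop.

The compounds shown leave open which part of the departing group matters: its sulfur, its six-membered aromatic ring or its chlorine. A methylsulfanyl group, a benzylsulfanyl group without chlorine or a simple amine on this same carbon would help separate these parts.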